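Adding fluoro to a compound sitting at a limit

A few compounds are considered here, and "the series" means these few. Any claim that something is new, unique, unknown or untested is made for them only; others in the source may bear on it.

Measured in a functional assay on HCT-116 cells (Homo sapiens) for inhibition, read by sulforhodamine B assay, with a stated time of 3 days; a higher number here means a weaker inhibitor of growth, a lower number a stronger inhibitor of growth:
compound 1 `O=C(/C=C/c1ccccc1Cl)c1ccc(OCc2ccccc2)cc1`: 14900 nM
compound 2 `Cc1ccc(COc2ccc(C(=O)/C=C/c3ccccc3)cc2)cc1`: > 50000 nM
compound 3 `O=C(/C=C/c1ccccc1)c1ccc(OCc2ccccc2)cc1`: > 50000 nM

Compound 3 gives > 50000 nM, which is a limit of the assay and not a number. Compound 2 also gives a limit, > 50000 nM. The step therefore starts from no exact value.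

Compound 4 `O=C(/C=C/c1ccc(F)cc1)c1ccc(OCc2ccccc2)cc1` differs from compound 3 by a single change: fluoro in place of hydrogen on an aromatic carbon. In words, phenyl becomes 4-fluorophenyl.

Among the compounds with values here, two measured steps bear on this. The chloro change shows an at least 3.3-fold higher number from compound 1 to compound 3 (0.52 log units; beyond the scatter), so in this one pair the chloro compound was the stronger inhibitor of growth. The methyl change gives a step that the two limits leave unreadable from compound 2 to compound 3, which offers no usable size. Fluoro is a different group from chloro, so the guidance is weak. A modest fall in the number in this assay is expected, though compound 4 may also stay at the limit. The estimated size is an at least 1.6-fold lower number from compound 3 to compound 4 (0.22 log units; that floor lies within the scatter). For compound 4 the estimate is 30000 nM, with an expected range of 12000 nM to 50000 nM.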

Compound 4, concentration for 50% growth inhibition: > 50000 nM
Compound 4 was reported as a limit; the forecaster's own chance of this, stated with the estimate: 45%; middle value at least 1.6-fold (0.22 log units) from the limit.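

Compound 4 gives > 50000 nM in this assay, which is a limit and not a number. Steps with a limit at both ends cannot be read, so fluoro on this ring, para to a large group, shows no gain that can be measured, and most of this small set sits at the same ceiling: the limit of > 50000 nM in this assay, at which 3 of the 4 values shown sit. The new comparison is between two halogen-bearing rings: the 2-chlorophenyl ring holds a clear lead over the 4-fluorophenyl ring, with an at least 3.3-fold higher number from compound 1 to compound 4 (0.52 log units; beyond the scatter).

On these data alone, that pair changes both the halogen and its place on the ring, so it remains open whether the lead belongs to chloro itself or to where it sits. As far as these compounds go, it is also open whether a 4-chlorophenyl ring, or a ring bearing an amine, would bring the number below the limit.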